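The source may hold more compounds than are shown below. What is called first, only, known or untested is meant among the compounds shown, and "the series" means these compounds.

Measured so far in a physicochemical assay for solubility, read by spectrophotometry, in phosphate buffer, measured as kinetic solubility, with a stated time of 18 h, at pH 7.4; a lower number here means a less soluble compound, a higher number a more soluble compound:
- compound 1 `O=C(Nc1ccc(F)c(-c2nc3ccccc3o2)c1)c1cc([N+](=O)[O-])ccc1Cl` gives 270 nM
- compound 2 `Cc1ccc(-c2nc3ccccc3s2)cc1NC(=O)c1cc([N+](=O)[O-])c(N(C)C)cc1Cl` gives 30 nM
- compound 3 `O=C(Nc1ccc(F)c(-c2nc3ccccc3s2)c1)c1cc([N+](=O)[O-])ccc1Cl` gives 490 nM

Compound 3 sits with compound 1 at the upper end of these three numbers, the pair lying within the scatter of each other. Compound 3 stands well clear of compound 2, beyond the scatter.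

The next case is compound 4 `COc1ccc(NC(=O)c2cc([N+](=O)[O-])ccc2Cl)cc1-c1nc2ccccc2s1`, with methoxy in place of fluoro on an aromatic carbon, ortho to a 1,3-benzothiazol-2-yl group (methoxy in place of fluoro on an aromatic carbon). Going by the values given here, no measured step covers this exchange. Among the compounds with values here, the only single-place step, a 1.8-fold higher number from compound 1 to compound 3 (0.26 log units; within the scatter), concerns a different group and is small. Compound 2 differs from compound 3 in more than one place, so its gap cannot be assigned to any one change.

With so little to go on, no shift beyond the scatter is expected in this assay, with only a weakly supported lean downward. The expected step is a 1.6-fold lower number from compound 3 to compound 4 (0.21 log units; within the scatter). The estimate for compound 4 is 300 nM, with an expected range from 100 nM to 900 nM.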

Compound 4, solubility: 260 nM
Compound 4: middle estimate off by 1.2-fold (0.06 log units), on the high side; measured number inside the range.
By their numbers in this assay, from the lowest: compound 2; then compounds 4, 1 and 3 (each within the scatter of the next).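

At the aromatic carbon ortho to a 1,3-benzothiazol-2-yl group, the exchange of fluoro for methoxy gives, in this assay, a 1.9-fold lower number from compound 3 to compound 4 (0.28 log units; within the scatter). Going by these compounds alone, this is the first single-place reading at this position, and it shows that methoxy, which brings a hydrogen-bond acceptor and more heavy atoms than fluoro, leaves the number within the scatter for this one pair. No measured property bears on this step, so the result carries no explanation.

As far as these compounds go, it remains open whether any group at this position moves the number beyond the scatter, for example an amine, a carboxylic acid or a longer alkoxy chain. From the compounds shown here alone, it is equally open whether methoxy in place of fluoro reads the same with 1,3-benzoxazol-2-yl as the neighbouring group.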